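A few compounds are considered here, and "the series" means these few. Any claim that something is new, unique, unknown or untested is made for them only; others in the source may bear on it.

Measured compounds:
compound 1, `CC1=C(C(=O)OC(C)(C)C)C(c2cccs2)NC(=O)N1`, 38%
compound 2, `CC1=C(C(=O)OC(C)(C)C)C(c2ccsc2)NC(=O)N1`, 47%
compound 3, `COC(=O)C1=C(C)NC(=S)NC1c1cccs1`, 10%

All three were tested in an assay on membranes from HEK293 cells for displacement of a labelled ligand from adenosine receptor A2b (Homo sapiens), read by scintillation counting, with a stated time of 30 min, tested at 1 uM; a lower number here means less inhibition, a higher number more inhibition at the concentration tested (going by the name of the read-out). Compound 1 gives 38% and compound 2 gives 47%; the step of a number 9 percentage points higher from compound 1 to compound 2 (within the scatter) came with the change (thiophen-3-yl in place of thiophen-2-yl on a saturated ring carbon). Compound 3 gives 10%, the lowest of the three. How the core of compound 3 differs from the core of compound 1 is not broken down here. Compound 4, `COC(=O)C1=C(C)NC(=S)NC1c1ccsc1`, has not been measured; it arises from compound 3 through (thiophen-3-yl in place of thiophen-2-yl on a saturated ring carbon), the same kind of change as in compound 1 to compound 2, though here the saturated ring carbon is next to the ring atom that bears a methoxycarbonyl group rather than a group of 7 heavy atoms. Because the earlier step of a number 9 percentage points higher from compound 1 to compound 2 (within the scatter) was small, the step expected for compound 4 is a number 7 percentage points higher from compound 3 to compound 4 (within the scatter). The estimate for compound 4 is 17%, from 3% to 33%.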

Compound 4, a percentage reported as inhibition, at one concentration (the size of the read-out at that concentration, not a potency): 38%
The estimate for compound 4 lay 21 percentage points below the measured number; the measured number lies above the stated range.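

In this assay, thiophen-3-yl in place of thiophen-2-yl on a saturated ring carbon gives a number 28 percentage points higher from compound 3 to compound 4 (beyond the scatter), and the size of this change does not carry over from one core to the other: the same change on two cores in this assay, a number 9 percentage points higher (within the scatter) from compound 1 to compound 2 and a number 28 percentage points higher (beyond the scatter) from compound 3 to compound 4, 19 percentage points apart, beyond the scatter of two such steps Only on the core of compound 3 does the change stand beyond the scatter. This does not show which difference between the two cores matters, as they differ in more than one place and no pair shown separates those differences.

The compounds shown leave open how the change would behave on any further core. They also leave open how a phenyl or furan-2-yl ring on the same saturated ring carbon would compare with the two thiophene rings.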